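Trimming the chain end of a terpenoid quinone

This account rests on a few compounds, and the source may have more. Where it says the series, first, only, none or still open, it means among the compounds named here.

Measured so far:
- compound 1 `COC1=C(OC)[C@H](O)[C@H](C/C=C(\C)CC/C=C(\C)C[C@H](O)/C=C(\C)CO)[C@@H](C)C1=O`: 12000 nM
- compound 2 `COC1=C[C@H](O)[C@H](C/C=C(\C)CC/C=C(\C)C[C@H](O)/C=C(\C)CO)[C@@H](C)C1=O`: > 30000 nM

In a functional assay on A549 cells (Homo sapiens) for inhibition, read by sulforhodamine B assay, with a stated time of 48 h (on this read-out lower numbers stand for stronger inhibition of growth and higher numbers for weaker inhibition of growth), compound 1 gives 12000 nM. Going by the values given here, it is the only compound with a number in this assay. Compound 2 reaches only (the limit of > 30000 nM in this assay, at which 1 of the 2 values shown sits); this is a limit of the assay, not a number. The move to compound 2 replaces a group on the core, and it is a step of an at least 2.5-fold higher number from compound 1 to compound 2 (0.39 log units; beyond the scatter).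

Compound 3 `COC1=C(OC)[C@H](O)[C@H](C/C=C(\C)CC/C=C(\C)C/C=C/C(C)(C)O)[C@@H](C)C1=O` keeps the core of compound 1 unchanged and alters only the end of the side chain: a group of 6 heavy atoms (5 carbon, 1 oxygen; no ring) in place of a group of 7 heavy atoms (5 carbon, 2 oxygen; no ring), on a saturated chain carbon bound to a double-bonded chain carbon. Among the compounds with values here, the one measured step, from compound 1 to compound 2, concerns the core and not the chain, so no measured step bears directly on this change. With nothing pointing either way, the expectation is a step of a 1.3-fold higher number from compound 1 to compound 3 (0.10 log units; within the scatter), that is, no change beyond the scatter. Compound 3 is therefore estimated at 15000 nM in this assay, with a range from 5000 nM to 40000 nM.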

Compound 3, concentration for 50% growth inhibition: 23800 nM
Beside the measured number, compound 3's estimate is 1.6-fold (0.20 log units) below it; the range from low to high includes it.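

In this assay, the end of the side chain, on a saturated chain carbon bound to a double-bonded chain carbon, accepts the 3-hydroxy-3-methylbut-1-en-1-yl group with a step of a 2.0-fold higher number from compound 1 to compound 3 (0.30 log units; within the scatter) in this comparison. This is the first measured change at the chain end, and it shows that a group of 6 heavy atoms can stand in place of the original group of 7 without a difference that can be told from the scatter, so compound 1 and compound 3 cannot be ranked against each other, and the one step beyond the scatter among these compounds remains the change on the core. Nothing on hand bears on why the chain end responds this way.

Left open is whether a chain end carrying an amine or a carboxylic acid, or a longer chain, would move the number beyond the scatter in either direction. Also open, as far as these compounds go, is how the same chain-end change would behave on the core of compound 2, whose only reading so far is a limit of the assay and not a number.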